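Trifluoromethyl Acyl Urea Thiazole Hydrazones against BCG823 Cells

The source may report more compounds than this note shows. Statements on the series, on what has been measured and on what is new or still open speak of the compounds shown alone.

Three compounds of this series have numbers in a functional assay on BCG823 cells (Homo sapiens) for inhibition, read by MTT assay, with a stated time of 72 h; on this read-out lower numbers stand for stronger inhibition and higher numbers for weaker inhibition. Compound 1 `CN(C(=O)NC(=O)c1cccc(C(F)(F)F)c1)c1nc(C(F)(F)F)c(C(=O)N/N=C/c2ccccc2C(F)(F)F)s1` gives 7.29 ug/mL. Compound 2 `CN(C(=O)NC(=O)c1ccccc1F)c1nc(C(F)(F)F)c(C(=O)N/N=C/c2ccccc2C(F)(F)F)s1` gives 4.67 ug/mL. Compound 3 `CN(C(=O)NC(=O)c1ccccc1F)c1nc(C(F)(F)F)c(C(=O)N/N=C/c2cccc(C(F)(F)F)c2)s1` gives 16.3 ug/mL, the highest of the three.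

Compound 1 and compound 2 differ by 3-(trifluoromethyl)phenyl in place of 2-fluorophenyl on a carbonyl carbon, a change that gave a 1.6-fold higher number from compound 2 to compound 1 (0.19 log units; within the scatter). Compound 2 and compound 3 differ in their cores by 3-(trifluoromethyl)phenyl in place of 2-(trifluoromethyl)phenyl on a carbon with a double bond to nitrogen, which gave a 3.5-fold higher number from compound 2 to compound 3 (0.54 log units; beyond the scatter).

Compound 4 `CN(C(=O)NC(=O)c1cccc(C(F)(F)F)c1)c1nc(C(F)(F)F)c(C(=O)N/N=C/c2cccc(C(F)(F)F)c2)s1` is not yet measured in this assay. It differs from compound 3 by 3-(trifluoromethyl)phenyl in place of 2-fluorophenyl on a carbonyl carbon. Going by the values given here, this is the same change as the one from compound 2 to compound 1, made on the core of compound 3 instead of the core of compound 2, with the place described in the same words in both cases.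

The step from compound 3 to compound 4 is expected to be a 1.5-fold higher number from compound 3 to compound 4 (0.19 log units; within the scatter), resting on the earlier step because the same change gave a 1.6-fold higher number from compound 2 to compound 1 (0.19 log units; within the scatter). The number of compound 4 in this assay is therefore estimated at 25 ug/mL, with a range from 12 ug/mL to 55 ug/mL.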

Compound 4, half-maximal inhibitory concentration: 4.6 ug/mL
Beside the measured number, compound 4's estimate is 5.4-fold (0.74 log units) above it; the measured number lies below the stated range.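

In this assay, 3-(trifluoromethyl)phenyl in place of 2-fluorophenyl on a carbonyl carbon gives a 3.5-fold lower number from compound 3 to compound 4 (0.55 log units; beyond the scatter), so this change does not carry from one core to the other: the same change on two cores in this assay, a 1.6-fold higher number (0.19 log units; within the scatter) from compound 2 to compound 1 and a 3.5-fold lower number (0.55 log units; beyond the scatter) from compound 3 to compound 4, 5.5-fold (0.74 log units) apart, beyond the scatter of two such steps. 3-(trifluoromethyl)phenyl in place of 2-(trifluoromethyl)phenyl on a carbon with a double bond to nitrogen gives a 1.6-fold lower number from compound 1 to compound 4 (0.20 log units; within the scatter), and this change also depends on the core that carries it: the same change on two cores in this assay, a 3.5-fold higher number (0.54 log units; beyond the scatter) from compound 2 to compound 3 and a 1.6-fold lower number (0.20 log units; within the scatter) from compound 1 to compound 4, 5.5-fold (0.74 log units) apart, beyond the scatter of two such steps. The four compounds show that the effect of a change at one of these places depends on the group at the other, so a step read on one core is a poor guide to another in this series, but they do not show the reason for this or how far it extends beyond these two pairs of groups.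

Still open, going by these compounds, is whether the same dependence appears with other groups at either place, such as a plain phenyl, a carboxylic acid or an amine. Also open, on these data alone, is whether it holds on any other cell line.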